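Swapping Trifluoromethyl for Chloro on Compound 3

This account rests on a few compounds, and the source may have more. Where it says the series, first, only, none or still open, it means among the compounds named here.

Of the compounds shown here, three sharing one core have been tested in an assay on CHO cells for displacement of a labelled ligand from adenosine receptor A3 (Homo sapiens), read by scintillation counting, tested at 1 uM; on this read-out higher numbers stand for more inhibition at the one concentration tested (going by the name of the read-out) and lower numbers for less inhibition. Compound 1 `CCc1nc(N)c2nn(-c3ccccc3)cc2n1` gives 38%. Compound 2 `CC(C)Cc1nc(N)c2nn(-c3ccccc3)cc2n1` gives 13%. Compound 3 `Nc1nc(Cc2cccc(C(F)(F)F)c2)nc2cn(-c3ccccc3)nc12` gives 41%. On these numbers compound 3 stands highest of the three, though its gap to compound 1 lies within the usual scatter of repeated measurements, while its gap to compound 2 lies beyond it. Among the measured compounds shown here, the only step between measured compounds, isopropyl in place of methyl on a saturated chain carbon bound to an aromatic carbon, gave a number 25 percentage points lower from compound 1 to compound 2 (beyond the scatter).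

Compound 4 `Nc1nc(Cc2cccc(Cl)c2)nc2cn(-c3ccccc3)nc12` has not yet been measured. It differs from compound 3 in one place: chloro in place of trifluoromethyl on an aromatic carbon. The change sits on a six-membered aromatic ring of carbon only, meta to a large group. For the measured compounds named here, no measured step alters a group on that ring, so the one measured step, which changes a chain, does not bear on this change directly, and there is no basis for expecting a shift beyond the scatter. The expected step from compound 3 to compound 4 is therefore a number 1 percentage points lower from compound 3 to compound 4 (within the scatter). Compound 4 is estimated at 40%, with a range from 20% to 60%.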

Compound 4, a percentage reported as inhibition, at one concentration (the size of the read-out at that concentration, not a potency): 42%
For compound 4 the middle estimate is 2 percentage points below the measured one, and the stated range covers the measured number.
By their numbers in this assay, from the lowest: compound 2; then compounds 1, 3 and 4 (each within the scatter of the next).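

In this assay, chloro in place of trifluoromethyl on this aromatic carbon, meta to a large group, gives a number 1 percentage points higher from compound 3 to compound 4 (within the scatter) even though one heavy atom replaces four, so these two groups cannot be told apart here. The 3-chlorophenyl group in place of isopropyl gives a number 29 percentage points higher from compound 2 to compound 4 (beyond the scatter) and in place of methyl gives a number 4 percentage points higher from compound 1 to compound 4 (within the scatter) so compound 4 sits with compound 1 and compound 3 and clear of compound 2. Nothing available accounts for why the swap leaves the number within the scatter.

Whether a methoxy group, an amine or a bare hydrogen at this ring carbon would also hold the number is open. So is whether compound 3 and compound 4 would differ in potency, since each has a reading at one concentration only.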